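The compounds below may be only part of what the source reports. "The series", "measured", "known", "first", "only" and "open" are said of these compounds alone.

Compound 1 `COc1ccc(C2CC(c3ccccc3)=NN2C2=NC(=O)/C(=C3\C(=O)Nc4ccc(Br)cc43)S2)cc1` gives 510 nM in a functional assay on cells (Cancer cell lines, Homo sapiens) for cytotoxicity, read by sulforhodamine B assay, with a stated time of 48 h; on this read-out higher numbers stand for weaker inhibition of growth and lower numbers for stronger inhibition of growth. Compound 2 `COc1ccc(C2=NN(C3=NC(=O)/C(=C4\C(=O)Nc5ccccc54)S3)C(c3ccc(OC)cc3)C2)cc1` gives 91600 nM. Compound 3 `COc1ccc(C2=NN(C3=NC(=O)/C(=C4\C(=O)Nc5ccc(Br)cc54)S3)C(c3ccc(OC)cc3)C2)cc1` gives 430 nM.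

Compound 3 has the lowest number of the three. Compound 1 is nearest, and a 1.2-fold lower number from compound 1 to compound 3 (0.07 log units; within the scatter) stays within the scatter; compound 2 lies furthest, with a 210-fold lower number from compound 2 to compound 3 (2.33 log units; beyond the scatter). Compound 4 `COc1ccc(C2=NN(C3=NC(=O)/C(=C4\C(=O)Nc5ccc(Cl)cc54)S3)C(c3ccc(OC)cc3)C2)cc1` differs from compound 3 by chloro in place of bromo on an aromatic carbon. For the measured compounds named here, the one measured step that bears on this exchange, at the same aromatic carbon, was large: a 210-fold lower number from compound 2 to compound 3 (2.33 log units; beyond the scatter). Here a halogen is exchanged rather than removed, so a much smaller rise in this assay is expected, possibly none beyond the scatter. Compound 4 is therefore expected to give 1200 nM, within 300 nM to 8000 nM. The expected step is a 2.8-fold higher number from compound 3 to compound 4 (0.45 log units; beyond the scatter), a modest rise.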

Compound 4, concentration for total growth inhibition: 440 nM
Compound 4: middle estimate off by 2.7-fold (0.44 log units), on the high side, within the range that was stated.
By their numbers in this assay, from the lowest: compounds 3, 4 and 1 (each within the scatter of the next); then compound 2.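

At this aromatic carbon, chloro in place of bromo makes no difference that this assay can separate, as a 1.0-fold higher number from compound 3 to compound 4 (0.01 log units; within the scatter) shows. Chloro in place of hydrogen brings a 210-fold lower number from compound 2 to compound 4 (2.32 log units; beyond the scatter), so the large drop is not unique to bromo but is shared by both halogens. Nothing available explains this result. The compounds shown leave open whether the drop needs a halogen at all, or whether an amine or a nitrile at this carbon would give a similar number.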